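From 4-fluorophenyl to 2,6-dichlorophenyl on a shared core

This account rests on a few compounds, and the source may have more. Where it says the series, first, only, none or still open, it means among the compounds named here.

- compound 1 `O=C(CC(c1ccc(F)cc1)C(C(=O)Nc1ccccn1)C(=O)Nc1ccccn1)c1ccccc1`: "not active" (no number reported)
- compound 2 `O=C(CC(c1ccccc1)C(C(=O)Nc1ccccn1)C(=O)Nc1ccccn1)c1ccc(F)cc1`: "not active" (no number reported)
- compound 3 `O=C(CC(c1ccc(Cl)cc1)C(C(=O)Nc1ccccn1)C(=O)Nc1ccccn1)c1ccc(F)cc1`: 26800 nM

In a functional assay on NCI-H460 cells (Homo sapiens) for inhibition, read by MTT assay, with a stated time of 48 h (a higher number here means a weaker inhibitor, a lower number a stronger inhibitor), compound 1 has no single number and is reported as "not active" (no number reported), a result shared by compound 2. Only compound 3 gives a number, 26800 nM.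

Compound 4 `O=C(CC(c1c(Cl)cccc1Cl)C(C(=O)Nc1ccccn1)C(=O)Nc1ccccn1)c1ccccc1` is still to be measured. It carries 2,6-dichlorophenyl in place of 4-fluorophenyl on a saturated chain carbon bound to two saturated chain carbons.

With no number for compound 1, the step in this assay cannot be sized exactly. A modest move towards measurable inhibition is expected, though a result without a number remains quite possible. The closest numerical reference is compound 3 at 26800 nM. The estimated value for compound 4 is 30000 nM, with an expected range of 10000 nM to 80000 nM.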

Compound 4, half-maximal inhibitory concentration: 27400 nM
The estimate for compound 4 lay 1.1-fold (0.04 log units) above the measured number; the range from low to high includes it.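

Within the data shown here, compound 1 has no number in this assay, so no step to compound 4 can be read, and no measured evidence bears on the result. The compounds shown leave open how far replacing 4-fluorophenyl with 2,6-dichlorophenyl changes inhibition.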